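The source may report more compounds than this note shows. Statements on the series, on what has been measured and on what is new or still open speak of the compounds shown alone.

Compound 1, `N=C(N)N/N=C/c1c(-c2cccs2)nc2sccn12`, gives 12000 nM in a functional assay on cells (Cancer cell lines, Homo sapiens) for inhibition; a lower number here means a stronger inhibitor of growth, a higher number a weaker inhibitor of growth. Compound 2, `Cc1cc(-c2nc3sccn3c2/C=N/NC(=N)N)c(C)s1`, gives 15500 nM in this assay. Compound 3, `Cc1cc(-c2nc3n(c2/C=N/NC(=N)N)CCS3)c(C)s1`, gives 18600 nM in this assay.

All three measured compounds are weak inhibitors of growth, and their numbers lie close together. Compounds 1 and 2 share a core and differ by thiophen-2-yl in place of 2,5-dimethylthiophen-3-yl on an aromatic carbon; this change produced a 1.3-fold lower number from compound 2 to compound 1 (0.11 log units; within the scatter). Compound 3 carries a different core from compound 2; how the two cores differ is not broken down here, and the values of compounds 2 and 3 show little separation.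

Compound 4, `N=C(N)N/N=C/c1c(-c2cccs2)nc2n1CCS2`, has not yet been measured in this assay. It stands to compound 3 as compound 1 stands to compound 2: the change is thiophen-2-yl in place of 2,5-dimethylthiophen-3-yl on an aromatic carbon. The surroundings of the place are not identical, since in the core of compound 3 the carbon is also two ring bonds from two ring atoms that each bear a fused ring, so this is the same kind of change rather than the same change.

Within the data shown here, for compound 4 a step of a 1.3-fold lower number from compound 3 to compound 4 (0.12 log units; within the scatter) is expected, of about the same size as the one from compound 2 to compound 1, because a 1.3-fold lower number from compound 2 to compound 1 (0.11 log units; within the scatter) is the only measured example of this kind of change. Compound 4 is therefore estimated at 14000 nM, with a range from 7000 nM to 30000 nM.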

Compound 4, concentration for 50% growth inhibition: 19100 nM
Beside the measured number, compound 4's estimate is 1.4-fold (0.13 log units) below it; measured number inside the range.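

Replacing 2,5-dimethylthiophen-3-yl with thiophen-2-yl on the core of compound 3 gives a 1.0-fold higher number from compound 3 to compound 4 (0.01 log units; within the scatter), so this pair cannot be told apart in this assay. Set beside the earlier step, the same kind of change gives results on the two cores that cannot be separated: the same change on two cores in this assay, a 1.3-fold lower number (0.11 log units; within the scatter) from compound 2 to compound 1 and a 1.0-fold higher number (0.01 log units; within the scatter) from compound 3 to compound 4, 1.3-fold (0.12 log units) apart, within the scatter of two such steps. This shows that, on both cores, the exchange of these two thiophene groups leaves the growth-inhibition number within the scatter; it does not show an effect of a definite size that carries from one core to the other, as neither step stands clear of the scatter, and two pairs say nothing about any further core.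

On these data alone, all four compounds keep a thiophene ring on this aromatic carbon, so it stays open whether a phenyl ring, an amine or a carboxylic acid there would move the number in this assay beyond the scatter on either core. Also open, as far as these compounds go, is what would follow if a shorter chain or a simple amide took the place of the group of 6 heavy atoms, which is the same in all four compounds.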